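A few compounds are considered here, and "the series" means these few. Any claim that something is new, unique, unknown or untested is made for them only; others in the source may bear on it.

Compound 1 (`COc1ccc(N(C)c2nc(C)nc3ccccc23)cc1OCCC[Se]C#N`) gives 815 nM in a functional assay on MDA-MB-231 cells (Homo sapiens) for inhibition, read by MTT assay, with a stated time of 48 h (a higher number here means a weaker inhibitor, a lower number a stronger inhibitor), and sits at the high end of the three measured numbers, level within the scatter with compound 3 (`COc1ccc(N(C)c2nc(C)nc3ccccc23)cc1C(=O)OCCCC[Se]C#N`), which gives 554 nM in this assay. Compound 2 (`COc1ccc(N(C)c2nc(C)nc3ccccc23)cc1[Se]C`) stands well apart at 10 nM in this assay.

Compound 4 (`COc1ccc(N(C)c2nc(C)nc3ccccc23)cc1OCCCC[Se]C#N`) keeps the core of compound 1 and changes only the end of the saturated chain: a group of 4 heavy atoms (2 carbon, 1 nitrogen, 1 selenium; no ring) in place of a group of 3 heavy atoms (1 carbon, 1 nitrogen, 1 selenium; no ring), on a saturated chain carbon, three bonds along the chain from an oxygen on an aromatic ring is the whole difference. Among the compounds with values here, no measured step isolates this change. The closest evidence is a 1.5-fold lower number from compound 1 to compound 3 (0.17 log units; within the scatter), which stays within the scatter although compound 3 carries the longer chain of compound 4 and joins it to the ring through an ester. The two large steps, an 82-fold lower number from compound 1 to compound 2 (1.91 log units; beyond the scatter) and a 55-fold higher number from compound 2 to compound 3 (1.74 log units; beyond the scatter), both replace the whole chain with a far smaller group, so they say little about a change this small.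

No step beyond the scatter is therefore expected in this assay, and the estimated change is a 1.3-fold lower number from compound 1 to compound 4 (0.10 log units; within the scatter) in size. Compound 4 is expected at 650 nM (estimated range 220 nM to 1900 nM) in this assay when it is measured.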

Compound 4, half-maximal inhibitory concentration: 1350 nM
Compound 4: the middle estimate sits 2.1-fold (0.32 log units) below what was measured; measured number inside the range.
By their numbers in this assay, from the lowest: compound 2; then compounds 3, 1 and 4 (each within the scatter of the next, the first and the last beyond it).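

The change at this saturated chain carbon, three bonds along the chain from an oxygen on an aromatic ring, now has a step of its own in this assay: the group of 4 heavy atoms in place of the group of 3 heavy atoms gives a 1.7-fold higher number from compound 1 to compound 4 (0.22 log units; within the scatter) and so leaves the number level within the scatter. With the longer chain held fixed, the link to the ring can now be read alone, and going from the ester to the oxygen link gives a 2.4-fold higher number from compound 3 to compound 4 (0.39 log units; beyond the scatter) as a modest step that the earlier pair, which changed chain length and link together, could not show. The small group on the aromatic carbon remains far apart, with a 140-fold higher number from compound 2 to compound 4 (2.13 log units; beyond the scatter) as the largest step in the set, and compound 2 stays the strongest inhibitor of the four.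

No measurement shown here accounts for any of these steps. Also open, from the compounds shown here alone, is whether a longer chain would stay level in the same way, and whether an amine or a carboxylic acid at the chain end would keep the number near that of compound 1.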